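The source may report more compounds than this note shows. Statements on the series, on what has been measured and on what is new or still open speak of the compounds shown alone.

Measured so far:
- compound 1, `Cc1cccc(N/C(S)=N/[C@@H](C)c2cccc3ccccc23)n1`: 1600 nM
- compound 2, `Cc1cc(C)nc(N/C(S)=N/[C@H](C)c2cccc3ccccc23)c1`: > 100000 nM

The account follows the step from compound 2 to compound 3. In a functional assay on RBL-2H3 cells (Rattus norvegicus) for inhibition (a higher number here means a weaker inhibitor, a lower number a stronger inhibitor), compound 1 gives 1600 nM. Compound 2 is the weaker of the two measured compounds, yet its result is not a number: in this assay compound 2 returns only the limit > 100000 nM. Going by these compounds, that is the point (the limit of > 100000 nM in this assay, at which 1 of the 2 values shown sits), so where compound 2 truly stands is unknown beyond that edge.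

Compound 3, `Cc1cc(C)nc(N/C(S)=N/[C@@H](C)c2cccc3ccccc23)c1`, is the partner of compound 2 that differs from it in one place: the two compounds have the same atoms and bonds and differ only in configuration as drawn: 1 of 2 stereo elements differ; a stereocentre at a saturated chain carbon is drawn R in compound 2 and S in compound 3. Within the data shown here, no measured pair shows what such a change alone does here, so the size of the step is open. Since compound 2 sits at a limit, a move in either direction toward a stronger inhibitor can only show up as a gain. The expectation for compound 3 is a step of an at least 33-fold lower number from compound 2 to compound 3 (1.52 log units; beyond the scatter) in this assay, toward stronger inhibition, beyond the usual scatter. Compound 3 is estimated at 3000 nM, with a range from 600 nM to 30000 nM.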

Compound 3, half-maximal inhibitory concentration: > 100000 nM
Compound 3 was reported as a limit; the forecaster's own chance of this, stated with the estimate: 25%; at least 33-fold (1.52 log units) between middle value and limit.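

In this assay, among these compounds, methyl in place of hydrogen on an aromatic carbon is the one change that can be read, and it goes with an at least 62-fold higher number from compound 1 to compound 3 (1.79 log units; beyond the scatter), a large loss of inhibition at this position. The value of compound 3, > 100000 nM, is a limit of the assay and not a number, so this step gives only a minimum size. The step between compound 2 and compound 3 cannot be read, and with this extra methyl present, neither the R nor the S drawing of the chain stereocentre gives a value inside the range of this assay: the limit of > 100000 nM in this assay, at which 2 of the 3 values shown sit.

Going by these compounds, it remains open how far the configuration at the chain carbon matters when hydrogen stands on that aromatic carbon, and how much separates compound 2 from compound 3 beyond their shared edge. Also open, on these data alone, is how a group other than methyl on that aromatic carbon, such as a chlorine atom, a methoxy group or an ethyl group, would read in this assay.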